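The source may hold more compounds than are shown below. What is called first, only, known or untested is meant among the compounds shown, and "the series" means these compounds.

Measured in a functional assay on Jurkat cells (Homo sapiens) for antiproliferative activity, read by MTT assay, with a stated time of 72 h; on this read-out higher numbers stand for weaker inhibition and lower numbers for stronger inhibition:
- compound 1 `COc1cc(C(=O)c2sc3ccccc3c2-c2ccc(C)cc2)cc(OC)c1OC`: 3300 nM
- compound 2 `COc1ccccc1-c1c(C(=O)c2cc(OC)c(OC)c(OC)c2)sc2ccccc12`: 2900 nM

For the measured compounds named here, compound 2 stands level with compound 1: the only measured step, a 1.1-fold lower number from compound 1 to compound 2 (0.06 log units; within the scatter), lies within the scatter. Compound 3 `COc1ccc(OC)c(-c2c(C(=O)c3cc(OC)c(OC)c(OC)c3)sc3ccccc23)c1` differs from compound 2 by methoxy in place of hydrogen on an aromatic carbon, which gives 2,5-dimethoxyphenyl. The measured step changed the same aromatic substituent but not this place on it, so it offers only loose guidance. In this assay, no change beyond the scatter is expected, in either direction. The estimated step is a 1.0-fold lower number from compound 2 to compound 3 (0.02 log units; within the scatter). The estimate for compound 3 is 2800 nM, with an expected range of 800 nM to 8000 nM.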

Compound 3, half-maximal inhibitory concentration: > 10000 nM
Compound 3 gave a limit, no number (the forecaster's own chance of this, stated with the estimate: 10%); middle value at least 3.5-fold (0.55 log units) away from the limit.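

In this assay, compound 3 gives > 10000 nM, a limit of the assay and not a number. Unlike the 2-methoxyphenyl for 4-methylphenyl change, this methoxy, para to a methoxy group, moves the read-out beyond the scatter towards weaker inhibition, with an at least 3.4-fold higher number from compound 2 to compound 3 (0.53 log units; beyond the scatter). The 2,5-dimethoxyphenyl in place of 4-methylphenyl likewise gives an at least 3.0-fold higher number from compound 1 to compound 3 (0.48 log units; beyond the scatter).

Going by these compounds, the true size of both steps stays open, as each has only a lower bound. Also open, on these data alone, is whether a hydroxy group or an amine on this carbon would give the same loss.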